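Swapping the Indole for a Chlorophenyl on the Amine

A few compounds are considered here, and "the series" means these few. Any claim that something is new, unique, unknown or untested is made for them only; others in the source may bear on it.

Compound 1 `O=C(/C=C\Nc1ccc(F)cc1)c1nc(-c2ccc(C(F)(F)F)cc2)n2ccccc12` reaches only the assay limit of > 30000 nM in a functional assay on A549 cells (Homo sapiens) for cytotoxicity, read by MTT assay, with a stated time of 48 h; a lower number here means a stronger inhibitor, a higher number a weaker inhibitor.
Compound 2 `O=C(/C=C\Nc1ccc2[nH]ccc2c1)c1nc(-c2ccc(C(F)(F)F)cc2)n2ccccc12` gives 5190 nM in this assay.

Among the compounds with values here, compound 2 holds the only full number here; the other value is a limit. Compound 3 `O=C(/C=C\Nc1ccc(Cl)cc1)c1nc(-c2ccc(C(F)(F)F)cc2)n2ccccc12` differs from compound 2 by 4-chlorophenyl in place of 1H-indol-5-yl on an amine nitrogen. Within the data shown here, the single measured step that bears on this, an at least 5.7-fold lower number from compound 1 to compound 2 (0.76 log units; beyond the scatter), runs the other way, from a 4-fluorophenyl to the indol-5-yl, with the weaker partner sitting at the limit of > 30000 nM in this assay, at which 1 of the 2 values shown sits. Replacing the indol-5-yl with a 4-chlorophenyl is expected to undo much of that gain, so a rise of roughly a 4.8-fold higher number from compound 2 to compound 3 (0.68 log units; beyond the scatter) is expected. Compound 3 is therefore estimated at 25000 nM, between 8000 nM and 60000 nM, and may well come back only as a limit.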

Compound 3, half-maximal inhibitory concentration: 18500 nM
Compound 3: the middle estimate sits 1.4-fold (0.13 log units) above what was measured; the range from low to high includes it.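

The 1H-indol-5-yl group now has a full number to be compared with, not just a limit: replacing it with 4-chlorophenyl on the amine nitrogen gives a 3.6-fold higher number from compound 2 to compound 3 (0.55 log units; beyond the scatter). Compound 1 gives only a limit, not a number: the limit of > 30000 nM in this assay, at which 1 of the 3 values shown sits. Chloro in place of fluoro on an aromatic carbon gives an at least 1.6-fold lower number from compound 1 to compound 3 (0.20 log units; that floor lies within the scatter), so no difference between these two halogens can be claimed.

On these data alone, it remains open whether a 4-methoxyphenyl or a benzofuran-5-yl on the same amine nitrogen would match the 1H-indol-5-yl group.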